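The source may report more compounds than this note shows. Statements on the series, on what has been measured and on what is new or still open speak of the compounds shown alone.

Measured so far in a functional assay on NB-4 cells (Homo sapiens) for cytotoxicity, read by CCK-8 assay, with a stated time of 24 h; a lower number here means a stronger inhibitor, a higher number a weaker inhibitor

compound 1 `C=CC(=O)N1C(=O)CC(c2ccc(C(F)(F)F)cc2)Sc2ccccc21` gives 38600 nM
compound 2 `C=CC(=O)N1C(=O)CC(c2ccc(-c3ccccc3)cc2)Sc2ccccc21` gives 57700 nM

For the measured compounds named here, compound 2 at 57700 nM lies within the scatter of compound 1, the only other measured compound. Compound 3 `C=CC(=O)N1C(=O)CC(c2ccc([N+](=O)[O-])cc2)Sc2ccccc21` has nitro in place of phenyl on an aromatic carbon, para to a large group, and nitro in place of phenyl on an aromatic carbon gives the counted change. Going by the values given here, with a 1.5-fold higher number from compound 1 to compound 2 (0.17 log units; within the scatter) as the only measured step at this place, no step beyond the scatter is expected in this assay for nitro, a group not yet tested. The expected step is a 1.4-fold lower number from compound 2 to compound 3 (0.16 log units; within the scatter) on this estimate. Compound 3 is estimated at 40000 nM with an expected range from 15000 nM to 90000 nM in these notes.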

Compound 3, half-maximal inhibitory concentration: 37700 nM
The estimate for compound 3 lay 1.1-fold (0.03 log units) above the measured number; low and high end bracket the measured number.
By their numbers in this assay, from the lowest: compounds 3, 1 and 2 (each within the scatter of the next).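

Working notes on the series, tested in (this assay): the aromatic carbon para to a large group now carries phenyl, trifluoromethyl or nitro, and neither new step leaves the scatter (a 1.5-fold lower number from compound 2 to compound 3 (0.18 log units; within the scatter); a 1.0-fold lower number from compound 1 to compound 3 (0.01 log units; within the scatter)). Replacing a six-membered aromatic ring of carbon only with nitro, which has no ring and counts hydrogen-bond acceptors, therefore gives no step beyond the scatter here. No available evidence bears on why these three numbers lie together. Open, on these data alone, is whether an amine, a carboxylic acid or a longer chain at this place would give a step beyond the scatter.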